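A few compounds are considered here, and "the series" means these few. Any claim that something is new, unique, unknown or untested is made for them only; others in the source may bear on it.

Measured compounds:
Compound 1, `COc1ccc(Cc2cnc(CCc3ccc(-c4ccccc4C(=O)O)cc3)[nH]2)cc1`, gives 5360 nM in an in vitro functional assay on cells for agonist activity at Bombesin receptor subtype-3 (Homo sapiens), read by luminescence and calcium flux; on this read-out higher numbers stand for an effect only at larger amounts of compound and lower numbers for an effect already at smaller amounts.
Compound 2, `O=C(O)c1ccccc1-c1ccc(CCc2ncc(Cc3ccccc3Cl)[nH]2)cc1`, gives 292 nM in this assay.
Compound 3, `O=C(O)c1ccccc1-c1ccc(CCc2ncc(Cc3cccc(F)c3)[nH]2)cc1`, gives 159 nM in this assay.

Compound 3 holds the lowest of the three numbers in this assay. Compound 2 lies within the scatter of it, whereas compound 1 stands clearly apart, with a 34-fold lower number from compound 1 to compound 3 (1.53 log units; beyond the scatter). The next compound, compound 4, `CC(C)(C)CCc1cnc(CCc2ccc(-c3ccccc3C(=O)O)cc2)[nH]1`, differs from compound 3 in one place: neopentyl in place of 3-fluorophenyl on a saturated chain carbon bound to an aromatic carbon. Going by the values given here, no measured step replaces the aromatic ring at this carbon with a chain. Among the compounds with values here, the steps that bear on it show only that this place carries large differences: an 18-fold lower number from compound 1 to compound 2 (1.26 log units; beyond the scatter) and a 34-fold lower number from compound 1 to compound 3 (1.53 log units; beyond the scatter) are both large, while a 1.8-fold lower number from compound 2 to compound 3 (0.26 log units; within the scatter) stays within the scatter. Since the entering neopentyl has no ring, a step upward in this assay is expected for compound 4, of uncertain size. Compound 4 is therefore estimated at 1000 nM, within 150 nM to 6000 nM. That estimate means an expected 6.3-fold higher number from compound 3 to compound 4 (0.80 log units; beyond the scatter).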

Compound 4, half-maximal effective concentration: 39 nM
The estimate for compound 4 lay 26-fold (1.41 log units) above the measured number; the measured number lies below the stated range.
By their numbers in this assay, from the lowest: compound 4; then compounds 3 and 2 (each within the scatter of the next); then compound 1.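

In this assay, compound 4 shows that an aromatic ring on this saturated chain carbon is not needed for a low number: neopentyl, which has no ring, gives a 4.1-fold lower number from compound 3 to compound 4 (0.61 log units; beyond the scatter) and a 7.5-fold lower number from compound 2 to compound 4 (0.87 log units; beyond the scatter) and also a 140-fold lower number from compound 1 to compound 4 (2.14 log units; beyond the scatter). The earlier compounds shown here varied this place only among substituted phenyl groups, while compound 4 carries a carbon chain there and holds the lowest number of the four, with each of its steps beyond the scatter. Nothing measured on these compounds accounts for this result. The compounds shown leave open whether the result depends on the branched end of neopentyl or would also hold for a straight pentyl chain, a cyclohexyl ring or a shorter chain. They also leave open how a chain ending in an amine or a hydroxyl group would read at this place in this assay.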